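The source may report more compounds than this note shows. Statements on the series, on what has been measured and on what is new or still open speak of the compounds shown alone.

In an ADME assay on CHO cells (Cricetulus griseus) for cytotoxicity, read by MTT assay, with a stated time of 24 h (a lower number here means that less compound is tolerated, a higher number that more compound is tolerated), compound 1 (`CC1Cn2c(nc([N+](=O)[O-])c2-c2ccccc2)O1`) gives only a limit, > 500000 nM. Compound 2 (`CCCOc1ccc(-c2c([N+](=O)[O-])nc3n2CC(C)O3)cc1`) also gives only a limit, > 125000 nM, so no exact number fixes where it stands, and neither of the two values shown is a measured number. Compound 3 (`CC1Cn2c(nc([N+](=O)[O-])c2-c2ccc(OC(F)(F)F)cc2)O1`) differs from compound 2 by trifluoromethyl in place of propyl on an oxygen on an aromatic ring, which is trifluoromethyl in place of propyl on an oxygen on an aromatic ring, or propoxy to trifluoromethoxy. Within the data shown here, the only measured step that bears on this change is a step that the two limits leave unreadable from compound 1 to compound 2, with propoxy in place of hydrogen on an aromatic carbon, and it offers no size to carry over. No change beyond the scatter is therefore expected in this assay, in either direction. The expected step is a step that the limit leaves unreadable from compound 2 to compound 3. For compound 3 the estimated value is 200000 nM, with an expected range of 70000 nM to 500000 nM.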

Compound 3, half-maximal cytotoxic concentration: > 125000 nM
Compound 3: no number, only a limit (the forecaster's own chance of this, stated with the estimate: 70%); the middle value lies beyond the limit too.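

In this assay compound 3 gives only a limit, > 125000 nM. Among these compounds, compound 1 and compound 2 also give only limits, so no step among the three can be read. The compounds shown leave open at what concentration each becomes cytotoxic, and whether hydrogen, propoxy or trifluoromethoxy makes any difference.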